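The source may hold more compounds than are shown below. What is called first, only, known or untested is meant among the compounds shown, and "the series" means these compounds.

Measured compounds:
compound 1 `Nc1ccccc1NC(=O)c1ccc(NCc2nc(-c3ccccc3)nn2-c2ccccc2)cc1` — 5%
compound 2 `NNC(=O)c1ccc(NCc2nc(-c3ccccc3)nn2-c2ccccc2)cc1` — 10%

In an assay on Sf9 cells for inhibition of protein deacetylase HDAC6 (Homo sapiens), read by fluorescence, with a stated time of 40 min, tested at 100 nM (a higher number here means more inhibition at the concentration tested (going by the name of the read-out), a lower number less inhibition), compound 1 gives 5% and compound 2 gives 10%. Within the data shown here, of the two numbers, the one for compound 2 is nominally the upper, but the step of a number 5 percentage points higher from compound 1 to compound 2 (within the scatter) lies within the scatter, so the two compounds are not separated by this assay; both sit near the bottom of the scale.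

Compound 3 `CNC(=O)c1ccc(NCc2nc(-c3ccccc3)nn2-c2ccccc2)cc1` differs from compound 2 by methyl in place of amino on an amide-type nitrogen. Among the measured compounds shown here, only one measured step is available, the step from compound 1 to compound 2, which changed the group on the same amide-type nitrogen and was within the scatter. For the measured compounds named here, it is not the same exchange as the present one, so it bears only loosely on the change to compound 3, and no step touching a methylcarbamoyl has been measured. Given that both measured values are low and the one measured step at this position stayed within the scatter, the expected step of a number 4 percentage points lower from compound 2 to compound 3 (within the scatter) is none beyond the scatter.

Compound 3 is therefore estimated at 6%, with a range from -5% to 20%.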

Compound 3, a percentage reported as inhibition, at one concentration (the size of the read-out at that concentration, not a potency): -3.6%
The estimate for compound 3 lay 9.6 percentage points above the measured number; the measured number falls inside the stated range.
By their numbers in this assay, from the lowest: compounds 3, 1 and 2 (each within the scatter of the next, the first and the last beyond it).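

In this assay, among these compounds, the exchange of amino for methyl on the amide-type nitrogen gives the first step at this position that clears the scatter, a number 13.6 percentage points lower from compound 2 to compound 3 (beyond the scatter), though it remains modest and compound 3, at -3.6%, stays at the bottom of the scale with the other two compounds. The step of a number 8.6 percentage points lower from compound 1 to compound 3 (within the scatter) stays within the scatter, so the position separates methyl from amino but separates neither from 2-aminophenyl, and the only difference counted for the 2>3 exchange is that amino carries a hydrogen-bond donor and acceptor while methyl carries neither. No supporting measurement is available to account for this step.

All three values come from a single concentration and lie close to the floor of the read-out, so they show no substituent at this position that gives substantial inhibition and offer no potency ranking. On these data alone, whether a hydroxyl on the same amide-type nitrogen, or a longer chain such as ethyl in place of methyl, would lift the number clear of this low band remains open.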